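The compounds below may be only part of what the source reports. "The series", "measured", "known", "first", "only" and "open" are said of these compounds alone.

Measured so far:
- compound 1 `CC(C)c1cccc(C(C)C)c1NC(=O)NCC1(c2ccccc2)CCCCC1`: 21 nM in an assay on microsomes from intestine for inhibition of acyl-CoA:cholesterol acyltransferase (Oryctolagus cuniculus); on this read-out lower numbers stand for stronger inhibition and higher numbers for weaker inhibition
- compound 2 `CC(C)c1ccccc1NC(=O)NCC1(c2ccccc2)CCCCC1`: 390 nM
- compound 3 `CCc1cccc(CC)c1NC(=O)NCC1(c2ccccc2)CCCCC1`: 51 nM

Among these three, compound 3 gives the second highest number: its value lies above that of compound 1 and well below that of compound 2. Compound 4 `CCc1cccc(C(C)C)c1NC(=O)NCC1(c2ccccc2)CCCCC1` differs from compound 3 in one place: methyl in place of hydrogen on a saturated chain carbon bound to an aromatic carbon and a saturated chain carbon. Put differently, one of the two ethyl groups on the aromatic ring of compound 3 becomes an isopropyl, so compound 4 sits halfway between compound 3 and compound 1 in this respect.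

Among the compounds with values here, the one measured single-point step bears on it only loosely: removing a whole isopropyl gave a 19-fold higher number from compound 1 to compound 2 (1.27 log units; beyond the scatter), a large loss. Here nothing is removed; one group merely grows by a single carbon. Compound 3 and compound 1 themselves show that the diisopropyl pattern gives the lower number of the two, so the change is expected to lower the number somewhat, by a 1.6-fold lower number from compound 3 to compound 4 (0.20 log units; within the scatter), a step expected to be smaller than the loss seen from compound 1 to compound 2. For compound 4 the expected value in this assay is 32 nM, with a likely range of 15 nM to 70 nM.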

Compound 4, half-maximal inhibitory concentration: 20 nM
Compound 4: the middle estimate sits 1.6-fold (0.20 log units) above what was measured; the range from low to high includes it.
By their numbers in this assay, from the lowest: compounds 4 and 1 (each within the scatter of the next); then compound 3; then compound 2.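

In this assay, growing one ethyl into an isopropyl gives a 2.6-fold lower number from compound 3 to compound 4 (0.41 log units; beyond the scatter) and shows that a single added methyl on this saturated chain carbon can shift the number beyond the scatter. Trimming one isopropyl back to ethyl gives a 1.1-fold lower number from compound 1 to compound 4 (0.02 log units; within the scatter) and leaves the two numbers indistinguishable, so among these compounds, one ethyl with one isopropyl does as well as two isopropyl groups. Adding an ethyl in place of hydrogen on an aromatic carbon gives a 20-fold lower number from compound 2 to compound 4 (1.29 log units; beyond the scatter) and shows that an ethyl can fill that place with a large gain, not only an isopropyl.

On these data alone, whether a methyl, a tert-butyl or a methoxy group in that place would hold the number stays open. Nothing available explains why the added methyl shifts the number.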